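Ethyl in Place of Cyclohexyl on the Ether Oxygen

The source may report more compounds than this note shows. Statements on the series, on what has been measured and on what is new or still open speak of the compounds shown alone.

Compound 1 `CCCOCNc1n[n+]([O-])c2cc(OC)ccc2[n+]1[O-]`: 1070 nM
Compound 2 `[O-][n+]1nc(NCOC2CCCCC2)[n+]([O-])c2ccccc21`: 4170 nM
Compound 3 `[O-][n+]1nc(NCOCc2ccccc2)[n+]([O-])c2ccccc21`: 4790 nM

In a functional assay on SMMC-7721 cells (Homo sapiens) for cytotoxicity, read by MTT assay, with a stated time of 72 h (a higher number here means a weaker inhibitor, a lower number a stronger inhibitor), compound 2 gives 4170 nM, the second highest of the three numbers; compound 3 sits within the scatter of it, while compound 1 lies further away at a lower number. Compound 4 `CCOCNc1n[n+]([O-])c2ccccc2[n+]1[O-]` differs from compound 2 by ethyl in place of cyclohexyl on an oxygen on a saturated carbon. Going by the values given here, only one measured step bears on this place: a 1.1-fold higher number from compound 2 to compound 3 (0.06 log units; within the scatter), which did not leave the scatter. Compound 1, which carries propyl at the same oxygen but also a methoxy group on its core, gives 1070 nM, so no clean comparison for a small chain exists. Compound 4 is therefore expected to show a 1.7-fold lower number from compound 2 to compound 4 (0.22 log units; within the scatter), a modest shift toward a lower number. The estimate for compound 4 is 2500 nM, within 1000 nM to 6000 nM.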

Compound 4, half-maximal inhibitory concentration: 4230 nM
Estimate against measurement, compound 4: 1.7-fold (0.23 log units) below; measured number inside the range.
By their numbers in this assay, from the lowest: compound 1; then compounds 2, 4 and 3 (each within the scatter of the next).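

In this assay the group on this oxygen can shrink as well as gain an aromatic ring without leaving the scatter: the steps read (a 1.0-fold higher number from compound 2 to compound 4 (0.01 log units; within the scatter)) and (a 1.1-fold lower number from compound 3 to compound 4 (0.05 log units; within the scatter)). Ethyl, with 2 heavy atoms and no ring, thus reads alike with cyclohexyl, with 6 heavy atoms, so ring and size show no effect across these three compounds. Nothing measured here explains this flat reading.

The compounds shown leave open whether an amine or a carboxylic acid on a chain at this oxygen would move the number. The methoxy group on the core of compound 1 also remains unresolved, as that compound differs from the others in more than one place.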